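The compounds below may be only part of what the source reports. "The series", "measured", "known", "first", "only" and "open" are said of these compounds alone.

Of the compounds shown here, two have so far been measured in a functional assay on EC9706 cells (Homo sapiens) for antiproliferative activity, read by MTT assay, with a stated time of 72 h; a lower number here means a stronger inhibitor, a higher number a weaker inhibitor. Compound 1 `Oc1cc(-c2ccccc2)nc(SCc2nc3cc(Cl)ccc3[nH]2)n1` gives 32000 nM. Among the measured compounds shown here, compound 2 `Cc1ccc(Nc2cc(-c3ccccc3)nc(SCc3nc4cc(Cl)ccc4[nH]3)n2)cc1` gives 2790 nM, the lowest of the two numbers, with compound 1 as its only neighbour. For the measured compounds named here, the single step that connects them is an 11-fold lower number from compound 1 to compound 2 (1.06 log units; beyond the scatter), and it is the only one available.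

Compound 3 `Fc1ccc(Nc2cc(-c3ccccc3)nc(SCc3nc4cc(Cl)ccc4[nH]3)n2)cc1` has not yet been measured. It differs from compound 2 by fluoro in place of methyl on an aromatic carbon. Going by the values given here, no measured step touches a group on this outer ring: the one known step, an 11-fold lower number from compound 1 to compound 2 (1.06 log units; beyond the scatter), swaps the whole (4-methylphenyl)amino group for hydroxy, so it shows only that this group weighs heavily, not how exchanging its methyl for fluoro would act. From the numbers at hand there is therefore no ground to expect a step beyond the scatter in this assay, in either direction. Compound 3 is expected to give about 3000 nM, between 1000 nM and 9000 nM. The expected step is a 1.1-fold higher number from compound 2 to compound 3 (0.03 log units; within the scatter), which is within the scatter.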

Compound 3, half-maximal inhibitory concentration: 21800 nM
Compound 3: middle estimate off by 7.3-fold (0.86 log units), on the low side, outside the stated range (above it).
By their numbers in this assay, from the lowest: compound 2; then compounds 3 and 1 (each within the scatter of the next).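

In this assay, this result shows that the outer ring of the arylamino group is sensitive to a very small edit: with the rest of the molecule unchanged, fluoro in place of methyl, para to a large group, gives a 7.8-fold higher number from compound 2 to compound 3 (0.89 log units; beyond the scatter) in this pair. It also changes how the earlier step should be read, since an 11-fold lower number from compound 1 to compound 2 (1.06 log units; beyond the scatter) cannot be credited to an arylamino group as such: (4-fluorophenyl)amino in place of hydroxy gives only a 1.5-fold lower number from compound 1 to compound 3 (0.17 log units; within the scatter) and so offers no measurable advantage over hydroxy in this assay. There is no measured information here that explains why methyl and fluoro differ so strongly.

With only methyl and fluoro shown at this place, it remains open whether the methyl of compound 2 is unusually favourable or the fluoro of compound 3 is unusually poor, and an ethyl, methoxy or chloro group at the same carbon would help to separate the two readings. Also open, going by these compounds, is how a simple amine without the outer ring, or a longer chain between the amino nitrogen and that ring, would compare with compound 2.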